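The compounds below may be only part of what the source reports. "The series", "measured", "known", "first", "only" and "open" are said of these compounds alone.

Measured in a functional assay on K562 cells (Homo sapiens) for inhibition, read by fluorescence, with a stated time of 72 h; on this read-out lower numbers stand for stronger inhibition of growth and higher numbers for weaker inhibition of growth:
- compound 1 `N[C@H]1CC[C@H](Nc2nc(Nc3ccc(Cl)cc3)c3ncn(C4CCCCC4)c3n2)CC1`: 1700 nM
- compound 2 `CC(C)CCn1cnc2c(NCc3cccc(Cl)c3)nc(N[C@H]3CC[C@H](N)CC3)nc21`: 3100 nM
- compound 3 `N[C@H]1CC[C@H](Nc2nc(Nc3ccc(O)cc3)c3ncn(C4CCCCC4)c3n2)CC1`: 8900 nM

Compound 3, at 8900 nM, has the highest number of the three. Compound 2 reads 3100 nM and compound 1 reads 1700 nM.

The next compound is compound 4 `CC(C)CCn1cnc2c(Nc3ccc(O)cc3)nc(N[C@H]3CC[C@H](N)CC3)nc21`, with isopentyl in place of cyclohexyl on an aromatic nitrogen.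

Going by the values given here, no measured pair isolates this change. Among the compounds with values here, the one measured single-place step is a 5.2-fold higher number from compound 1 to compound 3 (0.72 log units; beyond the scatter), a modest step for hydroxy in place of chloro on an aromatic carbon, which is a different place and bears on this change only indirectly. Compound 2 carries the isopentyl and gives 3100 nM, but it differs from compound 3 elsewhere too, so it offers only loose support.

From the compounds shown here alone, no step beyond the scatter is therefore expected in this assay, and the direction stays open. The estimated step is a 1.3-fold lower number from compound 3 to compound 4 (0.10 log units; within the scatter). The estimate for compound 4 is 7000 nM, with an expected range of 2500 nM to 20000 nM.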

Compound 4, concentration for 50% growth inhibition: 4600 nM
For compound 4 the middle estimate is 1.5-fold (0.18 log units) above the measured one; low and high end bracket the measured number.
By their numbers in this assay, from the lowest: compounds 1, 2, 4 and 3 (each within the scatter of the next, the first and the last beyond it).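

In this assay, isopentyl in place of cyclohexyl on the aromatic nitrogen gives a 1.9-fold lower number from compound 3 to compound 4 (0.29 log units; within the scatter), so this position does not separate the six-membered carbon ring from the open chain when 4-hydroxyphenyl is held constant. With isopentyl held constant, 4-hydroxyphenyl in place of 3-chlorobenzyl on a nitrogen on an aromatic ring gives a 1.5-fold higher number from compound 2 to compound 4 (0.17 log units; within the scatter), which also does not separate these two groups. Nothing available explains either step.

From the compounds shown here alone, whether the step from chloro to hydroxy seen with cyclohexyl also holds with isopentyl remains open. Also open, going by these compounds, is how a longer chain, an amine or a carboxylic acid on the aromatic nitrogen would read, as both groups compared here contain carbon only.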